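Inverting both stereocentres of compound 3

The source may report more compounds than this note shows. Statements on the series, on what has been measured and on what is new or still open speak of the compounds shown alone.

compound 1 `CCCNc1nc(Cl)nc(N[C@@H](C)c2ccccc2)n1`: 15100 nM
compound 2 `C[C@H](Nc1nc(Cl)nc(NC(C)(C)C)n1)c1ccccc1`: 7410 nM
compound 3 `CC[C@H](C)Nc1nc(Cl)nc(N[C@H](C)c2ccccc2)n1`: 52500 nM
compound 4 `CC[C@@H](C)Nc1nc(Cl)nc(N[C@@H](C)c2ccccc2)n1`: not yet measured

These numbers come from an ADME assay on the whole organism for inhibition, with Echinochloa crus-galli var. formosensis as the target, with a stated time of 4 days; on this read-out lower numbers stand for stronger inhibition and higher numbers for weaker inhibition. Compound 3 has the highest number of the three and is the weakest of them. Compound 4 is its mirror image: the two compounds have the same atoms and bonds and differ only in configuration as drawn: 2 of 2 stereo elements differ (all stereocentres are inverted: mirror images); a stereocentre at a saturated chain carbon is drawn S in compound 3 and R in compound 4; a stereocentre at a saturated chain carbon is drawn R in compound 3 and S in compound 4.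

Among the compounds with values here, no measured step inverts a stereocentre. Within the data shown here, the only step available, a 2.0-fold lower number from compound 1 to compound 2 (0.31 log units; beyond the scatter), places tert-butyl where propyl stood on a nitrogen on an aromatic ring. It is modest and offers only an indirect guide. One stereocentre of compound 4 is drawn as in compound 1 and compound 2, whereas compound 3 differs from both there. Compound 1 and compound 2 both show lower numbers than compound 3 at 52500 nM, so a lower number is expected for compound 4, although this rests on very few compounds. The expected change is a 3.5-fold lower number from compound 3 to compound 4 (0.54 log units; beyond the scatter). For compound 4 the estimated value is 15000 nM, with an expected range from 4000 nM to 60000 nM.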

Compound 4, half-maximal inhibitory concentration: 7410 nM
Compound 4: the middle estimate sits 2.0-fold (0.31 log units) above what was measured, within the range that was stated.
By their numbers in this assay, from the lowest: compounds 2 and 4 (each within the scatter of the next); then compound 1; then compound 3.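

In this assay, within the data shown here, a 7.1-fold lower number from compound 3 to compound 4 (0.85 log units; beyond the scatter) is the first measured effect of configuration, and it can be assigned to stereochemistry alone for one reason: the fact that compounds 3 and 4 differ only in the configuration as drawn. With this configuration, sec-butyl in place of tert-butyl on a nitrogen on an aromatic ring gives no change at the digits printed from compound 2 to compound 4 (within the scatter), so these two branched groups cannot be told apart here. Methyl in place of hydrogen on a saturated chain carbon, turning the propyl-bearing compound into its sec-butyl counterpart, gives a 2.0-fold lower number from compound 1 to compound 4 (0.31 log units; beyond the scatter).

Both stereocentres differ together in this pair, so the compounds shown do not reveal how much each one contributes. On these data alone, it also remains open how a longer chain such as pentyl, or an amine-bearing chain, on that nitrogen would read out.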